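Dichlorophenoxy in place of nitrophenoxy on the shared core

The source may hold more compounds than are shown below. What is called first, only, known or untested is meant among the compounds shown, and "the series" means these compounds.

Compound 1 `CC(C)[C@H](NC(=O)COc1cccc2ccccc12)C(=O)N[C@@H](CC(=O)O)C(=O)COc1cc(C(F)(F)F)cc(C(F)(F)F)c1`, compound 2 `CC(C)[C@H](NC(=O)COc1cccc2ccccc12)C(=O)N[C@@H](CC(=O)O)C(=O)COc1ccc(Oc2ccc(C(F)(F)F)cc2)cc1` and compound 3 `CC(C)[C@H](NC(=O)COc1cccc2ccccc12)C(=O)N[C@@H](CC(=O)O)C(=O)COc1ccc([N+](=O)[O-])cc1` share one core and differ only in the aryl group on the oxygen on a saturated carbon. In a functional assay on Jurkat cells (Homo sapiens) (a higher number here means a weaker inhibitor, a lower number a stronger inhibitor), compound 2 gives 9300 nM. Compound 1 reaches only a limit of this assay, > 100000 nM. Compound 3 likewise gives only a limit, > 100000 nM, so compound 3 stands at the limit of > 100000 nM in this assay, at which 2 of the 3 values shown sit, rather than at a number. Among the measured compounds shown here, the single measured step on this position is an at least 10-fold higher number from compound 2 to compound 3 (1.03 log units; beyond the scatter), a large loss.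

The next compound, compound 4 `CC(C)[C@H](NC(=O)COc1cccc2ccccc12)C(=O)N[C@@H](CC(=O)O)C(=O)COc1c(Cl)cccc1Cl`, carries 2,6-dichlorophenyl in place of 4-nitrophenyl on an oxygen on a saturated carbon. For the measured compounds named here, no measured step bears on this exact change; the step from compound 2 to compound 3 concerns the 4-(trifluoromethyl)phenoxy group, which neither compound 3 nor compound 4 carries. Compound 1 carries a substituted phenyl without that extension and sits at a limit. Compound 3 carries a substituted phenyl without that extension and sits at a limit. Compound 4 is therefore expected to stay near the limit, with an estimated step of an at least 1.2-fold lower number from compound 3 to compound 4 (0.09 log units; that floor lies within the scatter), none beyond the scatter. The estimated value for compound 4 in this assay is 80000 nM, within a range of 15000 nM to 300000 nM.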

Compound 4, half-maximal inhibitory concentration: 3000 nM
Estimate against measurement, compound 4: 27-fold (1.43 log units) above; measured number outside the range, below it.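

In this assay, 2,6-dichlorophenyl in place of 4-nitrophenyl gives an at least 33-fold lower number from compound 3 to compound 4 (1.52 log units; beyond the scatter), so a phenyl group without the 4-(trifluoromethyl)phenoxy extension can still give a measured number at this position on the shared core. Compound 4, at 3000 nM, also has a lower printed number than compound 2, at 9300 nM, so the 4-(trifluoromethyl)phenoxy group is not needed to obtain a measured value here. The limit therefore no longer covers every aryl group without that extension, although it still applies to part of the series: the limit of > 100000 nM in this assay, at which 2 of the 4 values shown sit.

Compound 4 differs from compound 3 in both the substituents and where they sit on the phenyl group, so this single step cannot separate the contribution of the two chlorines from that of their placement, and a phenyl group with one chlorine would bear directly on this. From the compounds shown here alone, whether the gain extends to other substituents on this phenyl group, such as an amine or a methoxy group, also remains open.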